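The compounds below may be only part of what the source reports. "The series", "measured", "known", "first", "only" and "open" are said of these compounds alone.

Measured in a functional assay on BMEC cells (Bos taurus) for antiproliferative activity; on this read-out lower numbers stand for stronger inhibition and higher numbers for weaker inhibition:
compound 1 `COc1cc(/C=C\Cc2cc(O)c3ccoc3c2)cc(OC)c1OC` gives 49 nM
compound 2 `COc1cc(/C=C/Cc2cc(O)c3ccoc3c2)cc(OC)c1OC` gives 27700 nM

Compound 1 holds the lower of the two numbers and is the stronger inhibitor of this pair. Among the compounds with values here, the only measured step is a 570-fold higher number from compound 1 to compound 2 (2.75 log units; beyond the scatter) and this large change stands with the fact that compounds 1 and 2 differ only in the configuration as drawn as its sole structural fact, the double bond being drawn Z in compound 1 and E in compound 2.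

Compound 3 `COc1cc(/C=C\Cc2cc(O)c3cc(C)oc3c2)cc(OC)c1OC` keeps the Z double bond of compound 1 and differs by methyl in place of hydrogen on an aromatic carbon as methyl in place of hydrogen on an aromatic carbon, on the five-membered aromatic ring with 1 oxygen, next to the ring oxygen. Within the data shown here, no measured step touches that place, so the large step above sets no size for this one. With compound 1 at 49 nM as the only reference carrying the Z double bond, no step beyond the scatter is the central expectation in this assay, with a weaker result the likelier departure. The estimated step is a 1.2-fold higher number from compound 1 to compound 3 (0.09 log units; within the scatter) and remains an expectation only. For compound 3 the estimated value is 60 nM with an expected range from 15 nM to 300 nM in this read-out.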

Compound 3, half-maximal inhibitory concentration: 93 nM
Compound 3: the middle estimate sits 1.6-fold (0.19 log units) below what was measured, and the stated range covers the measured number.
By their numbers in this assay, from the lowest: compounds 1 and 3 (each within the scatter of the next); then compound 2.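

In this assay, methyl in place of hydrogen on an aromatic carbon, next to the ring oxygen, gives a 1.9-fold higher number from compound 1 to compound 3 (0.28 log units; within the scatter), so compounds 1 and 3 cannot be told apart on this read-out. Within the data shown here, this is the first reading at this position of the five-membered aromatic ring with 1 oxygen, since the only earlier step concerned the geometry of the double bond; with the Z double bond kept, the added carbon leaves the number within the scatter. The information at hand includes no measured property that bears on this methyl change.

Still open, on these data alone, is whether this position accepts anything beyond methyl, such as an ethyl group, a longer chain, a primary amine or a carboxylic acid, since a single methyl sets no limit on size or type of group. Also open, as far as these compounds go, is whether the same methyl change would read the same way on the E double bond, and whether methyl on other carbons of the shared core would leave the number within the scatter as it does here.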